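Swapping pyridin-2-yl for 2-fluoropyridin-4-yl

The source may hold more compounds than are shown below. What is called first, only, known or untested is meant among the compounds shown, and "the series" means these compounds.

In an ADME assay on the whole organism (Rattus norvegicus) for pharmacokinetics, using cassette dosing, at a dose of 1 mg/kg by the oral route (on this read-out higher numbers stand for higher oral bioavailability and lower numbers for lower oral bioavailability), compound 1 (`C[C@@H](Cn1c(=O)[nH]/c(=N\c2ccc(Oc3ccc(F)cn3)cc2)n(Cc2ccc(Cl)cc2)c1=O)C(=O)O`) gives 82.4% and compound 2 (`C[C@@H](Cn1c(=O)[nH]/c(=N\c2ccc(Oc3ccccn3)cc2)n(Cc2ccc(Cl)cc2)c1=O)C(=O)O`) gives 52.8% as the lower of the two numbers. Compound 3 (`C[C@@H](Cn1c(=O)[nH]/c(=N\c2ccc(Oc3ccnc(F)c3)cc2)n(Cc2ccc(Cl)cc2)c1=O)C(=O)O`) keeps the rest of compound 2 and differs in one group (2-fluoropyridin-4-yl in place of pyridin-2-yl on an oxygen on an aromatic ring), with 2-fluoropyridin-4-yl in place of pyridin-2-yl on an oxygen on an aromatic ring. For the measured compounds named here, the one measured step that bears on this is modest and beyond the scatter (a number 29.6 percentage points lower from compound 1 to compound 2 (beyond the scatter)), a change of hydrogen in place of fluoro on an aromatic carbon. Going by the values given here, compound 3 also carries a fluoro that compound 2 lacks, but its group is not the one in compound 1, and no measured pair shows what the change of group alone does. The step expected in this assay is upward but smaller than the measured one (a number 12.2 percentage points higher from compound 2 to compound 3 (beyond the scatter)). Compound 3 is expected to reach an estimated 65% in a range from 40% to 88% in this measurement.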

Compound 3, oral bioavailability in the Rattus norvegicus assay: 43.2%
Estimate against measurement, compound 3: 21.8 percentage points above; low and high end bracket the measured number.
By their numbers in the Rattus norvegicus assay, from the lowest: compounds 3 and 2 (each within the scatter of the next); then compound 1.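

In the Rattus norvegicus assay, the swap of pyridin-2-yl for 2-fluoropyridin-4-yl on the oxygen cannot be told from no change (a number 9.6 percentage points lower from compound 2 to compound 3 (within the scatter)). A fluoro on the pyridine ring is therefore not enough to bring the number of compound 1, and the particular fluoropyridine matters, as 2-fluoropyridin-4-yl in place of 5-fluoropyridin-2-yl gives a number 39.2 percentage points lower from compound 1 to compound 3 (beyond the scatter). The swap from pyridin-2-yl does register in a physicochemical assay for solubility, at pH 6.8 (on this read-out lower numbers stand for lower solubility and higher numbers for higher solubility), where compound 2 gives 458 ug/mL and compound 3 gives 212 ug/mL: the measured solubility of compound 2, 458 ug/mL, and of compound 3, 212 ug/mL, a 2.2-fold lower number (0.33 log units; beyond the scatter)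

The compounds shown leave open whether the large step comes from where the ring is attached or from where the fluoro sits, a question that plain pyridin-4-yl would help to separate. They also leave open whether a chloro or a methoxy in place of the fluoro on 5-fluoropyridin-2-yl would hold the number of compound 1.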